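A Group Swap That Starts From a Limit

The source may report more compounds than this note shows. Statements on the series, on what has been measured and on what is new or still open speak of the compounds shown alone.

Of the compounds shown here, three sharing one core have been measured in a physicochemical assay for solubility, read by HPLC, in phosphate buffer, at pH 6.5; a lower number here means a less soluble compound, a higher number a more soluble compound. Compound 1 `COC(=O)C1=C(CN2CCNCC2)NC(c2nccs2)=NC1(C)c1ccc(F)cc1` gives 250 ug/mL. Compound 2 `COC(=O)C1=C(Cn2ccnc2)NC(c2nccs2)=NC1(C)c1ccc(F)cc1` gives 338 ug/mL, and a 1.4-fold higher number from compound 1 to compound 2 (0.13 log units; within the scatter) lies within the scatter. Compound 3 `COC(=O)C1=C(CN(C)C2(C(=O)O)CC2)NC(c2nccs2)=NC1(C)c1ccc(F)cc1` gives > 510 ug/mL, which is a limit of the assay and not a number. Compound 3 therefore stands at the limit of > 510 ug/mL in this assay, at which 1 of the 3 values shown sits.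

Compound 4 `COC(=O)C1=C(COC(C(=O)O)C(F)(F)F)NC(c2nccs2)=NC1(C)c1ccc(F)cc1` has not yet been measured, and its change is a group of 9 heavy atoms (3 carbon, 3 oxygen, 3 fluorine; no ring) in place of a group of 8 heavy atoms (5 carbon, 1 nitrogen, 2 oxygen; one three-membered non-aromatic ring of carbon only), on a saturated chain carbon bound to a double-bonded ring carbon. The leaving and entering groups each have 1 hydrogen-bond donor, 2 hydrogen-bond acceptors and no net charge.

Going by the values given here, two measured steps bear on this place, the saturated chain carbon bound to a double-bonded ring carbon. These are an at least 2.0-fold higher number from compound 1 to compound 3 (0.30 log units; that floor lies within the scatter) and an at least 1.5-fold higher number from compound 2 to compound 3 (0.17 log units; that floor lies within the scatter), and both floors lie within the scatter. On these data alone, neither step shows the entering group, so they offer only loose guidance, and the true number for compound 3 remains unknown. On these steps, no change beyond the scatter is expected in this assay, in either direction. The expected step is an at least 1.1-fold lower number from compound 3 to compound 4 (0.05 log units; that floor lies within the scatter). For compound 4 the estimate is 450 ug/mL, with an expected range of 180 ug/mL to 700 ug/mL.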

Compound 4, solubility: > 649 ug/mL
Compound 4 was reported as a limit; the forecaster's own chance of this, stated with the estimate: 40%; at least 1.4-fold (0.15 log units) between middle value and limit.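

In this assay compound 4 is reported as a limit and not a number: the limit of > 649 ug/mL in this assay, at which 1 of the 4 values shown sits. Going by these compounds alone, at the saturated chain carbon bound to a double-bonded ring carbon, the entering group with no ring gives the first step that is printed as beyond the scatter, an at least 2.5-fold higher number from compound 1 to compound 4 (0.41 log units; beyond the scatter), while the other readable step, an at least 1.9-fold higher number from compound 2 to compound 4 (0.28 log units; that floor lies within the scatter), remains a floor within the scatter, so the gain over compound 1 is now established but the gain over compound 2 is not. Compound 3 is also a limit and not a number, so the step from the group with the three-membered ring to the group with no ring cannot be read, and neither compound can be ranked over the other: the limit of > 510 ug/mL in this assay, at which 1 of the 4 values shown sits.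

On these data alone, the true values of compound 3 and compound 4 remain open, and with them the size of any difference between these two groups. Also open, as far as these compounds go, is what an open-chain amine, or a longer chain ending in a carboxylic acid without the fluorine atoms, would give at this place in this assay.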